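This account rests on a few compounds, and the source may have more. Where it says the series, first, only, none or still open, it means among the compounds named here.

In a functional assay on T47D cells (Homo sapiens) for activation (on this read-out higher numbers stand for an effect only at larger amounts of compound and lower numbers for an effect already at smaller amounts), compound 1 `CCNc1ccc2c(c1)OC(N)=C(C#N)C2c1cc(Br)c(OC)c(OC)c1` gives 14000000 nM, the lowest of the three numbers on hand. Compound 3 `CCNc1ccc2c(c1)OC(N)=C(C#N)C2c1cc(OC)c(OC)c(OC)c1` carries a methoxy where compound 1 carries a bromo; in this assay compound 3 gives 49000000 nM, and that change is a 3.5-fold higher number from compound 1 to compound 3 (0.54 log units; beyond the scatter). Compound 2 `COc1cccc(C2C(C#N)=C(N)Oc3cc(OC)ccc32)c1` shares the core and gives 52000000 nM, but it differs from compound 1 in more than one place, so its number and that of compound 1 can only be set side by side, not read as a step. The change followed here leads to compound 4 `CCOc1ccc2c(c1)OC(N)=C(C#N)C2c1cc(Br)c(OC)c(OC)c1`: ethoxy in place of ethylamino on an aromatic carbon. For the measured compounds named here, no measured step touches this kind of swap; the single step on hand, from a bromo to a methoxy, sits elsewhere in the structure and says nothing direct about replacing an ethylamino with an ethoxy. Going by the values given here, the one step that was measured was modest, and nothing on hand points to a large shift in either direction. Among the compounds with values here, with no guiding step, the expectation for compound 4 is a 1.4-fold higher number from compound 1 to compound 4 (0.15 log units; within the scatter), a shift not clearly beyond the scatter. Compound 4 is therefore estimated at 20000000 nM in this assay, with a range from 7000000 nM to 60000000 nM.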

Compound 4, half-maximal effective concentration: 64000000 nM
Beside the measured number, compound 4's estimate is 3.2-fold (0.51 log units) below it; the whole stated range lies below it.
By their numbers in this assay, from the lowest: compound 1; then compounds 3, 2 and 4 (each within the scatter of the next).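

Swapping ethylamino for ethoxy on this aromatic carbon gives a 4.6-fold higher number from compound 1 to compound 4 (0.66 log units; beyond the scatter) in this assay, so this position, which the earlier bromo-to-methoxy step did not touch, responds to a change beyond the scatter. The swap leaves the count of heavy atoms unchanged: a nitrogen gives way to an oxygen, and the count of hydrogen-bond donors falls from 1 to 0, so a small edit to the group is enough to move the number. No measurement on hand ties this shift to any particular property of either group.

From the compounds shown here alone, what remains open is whether the higher number follows from losing the nitrogen itself or the hydrogen on it, and how much the length of the chain matters; a dimethylamino group, a free amine or a longer propoxy chain at this place would help separate these possibilities. Going by these compounds, it is also open whether the same swap would produce a similar step on the core of compound 3, which carries a methoxy where compound 1 carries a bromo.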